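Piperidine amide replacing cyclopropyl amide on the isoxazolyl series

The compounds below may be only part of what the source reports. "The series", "measured", "known", "first", "only" and "open" are said of these compounds alone.

Measured so far:
- compound 1, `Cn1cc(-c2nn(Cc3ccc(C(=O)N4CCCCC4)cc3)c(=O)c3ccccc23)cn1`, in a functional assay on A549 cells (Homo sapiens) for antiproliferative activity, read by MTT assay, with a stated time of 72 h (a lower number here means a stronger inhibitor, a higher number a weaker inhibitor), gives 67400 nM
- compound 2, `Cc1noc(C)c1-c1nn(Cc2ccc(C(=O)NC3CC3)cc2)c(=O)c2ccccc12`, in this assay gives > 100000 nM

Compound 2 sits at the limit of this assay; its value of > 100000 nM is a limit and not a number, as the line the limit of > 100000 nM in this assay, at which 1 of the 2 values shown sits, records. Within the data shown here, compound 1 differs from compound 2 in more than one place, so the two values show only that compound 1 gives a number where compound 2 does not.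

Compound 3, `Cc1noc(C)c1-c1nn(Cc2ccc(C(=O)N3CCCCC3)cc2)c(=O)c2ccccc12`, is not yet measured. It differs from compound 2 by piperidin-1-yl in place of cyclopropylamino on a carbonyl carbon. Among the measured compounds shown here, no measured step separates these two compounds. The estimated step is an at least 1.2-fold lower number from compound 2 to compound 3 (0.09 log units; that floor lies within the scatter), a small one towards a measurable but weak value, though a limit remains possible. For compound 3 the estimate in this assay is 80000 nM, within 30000 nM to 200000 nM.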

Compound 3, half-maximal inhibitory concentration: 86200 nM
Beside the measured number, compound 3's estimate is 1.1-fold (0.03 log units) below it, within the range that was stated.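

In this assay, among these compounds, the first one-place comparison at the carbonyl carbon, piperidin-1-yl in place of cyclopropylamino, gives an at least 1.1-fold lower number from compound 2 to compound 3 (0.06 log units; that floor lies within the scatter), so the size of this change remains unresolved. The value of compound 2 is a limit and not a number: the limit of > 100000 nM in this assay, at which 1 of the 3 values shown sits.

With the piperidine amide held constant, 3,5-dimethyl-1,2-oxazol-4-yl in place of 1-methyl-1H-pyrazol-4-yl on an aromatic carbon gives a 1.3-fold higher number from compound 1 to compound 3 (0.11 log units; within the scatter), so this exchange does not separate the two compounds.

Still open, going by these compounds, is whether another group on the carbonyl carbon, such as morpholin-4-yl or dimethylamino, would give a step beyond the scatter. Also open, on these data alone, is how a carboxylic acid in place of the amide would read in this assay.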